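A few compounds are considered here, and "the series" means these few. Any claim that something is new, unique, unknown or untested is made for them only; others in the source may bear on it.

Measured compounds in a toxicity assay on HeLa cells (Homo sapiens) for cytotoxicity, read by MTT assay, with a stated time of 24 h; on this read-out lower numbers stand for stronger inhibition and higher numbers for weaker inhibition:
Compound 1 `CCOC(=O)N1CCN(C(=S)SCC(O)Cn2c([N+](=O)[O-])cnc2C)CC1` gives 1610000 nM.
Compound 2 `CCN1CCN(C(=S)SCC(O)Cn2c([N+](=O)[O-])cnc2C)CC1` gives > 5000000 nM, a limit of the assay rather than a number.
Compound 3 `CCOC(=O)N1CCN(CC(O)Cn2c([N+](=O)[O-])cnc2C)CC1` gives 3670000 nM.

Compounds 1 and 2 differ in one place: ethyl in place of ethoxycarbonyl on an amine nitrogen in a ring. This change gave an at least 3.1-fold higher number from compound 1 to compound 2 (0.49 log units; beyond the scatter), and the step is stated only as a lower bound because of the limit of > 5000000 nM in this assay, at which 1 of the 3 values shown sits. Compound 3 shares the ethoxycarbonyl group of compound 1 but the difference between the two cores is not broken down here. The unmeasured compound 4 `CCN1CCN(CC(O)Cn2c([N+](=O)[O-])cnc2C)CC1` differs from compound 3 by ethyl in place of ethoxycarbonyl on an amine nitrogen in a ring, the same change that turned compound 1 into compound 2. On the same change producing a similar weakening, the step from compound 3 to compound 4 in this assay is expected to be a 2.5-fold higher number from compound 3 to compound 4 (0.39 log units; beyond the scatter), resting on the step from compound 1 to compound 2 and on compound 3 already sitting at 3670000 nM. For compound 4 a value around 9000000 nM is estimated, between 4000000 nM and 25000000 nM, most likely reported only as a limit.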

Compound 4, half-maximal inhibitory concentration: 4940000 nM
Estimate against measurement, compound 4: 1.8-fold (0.26 log units) above; low and high end bracket the measured number.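

In this assay, putting ethyl in place of ethoxycarbonyl on an amine nitrogen in a ring gave a 1.3-fold higher number from compound 3 to compound 4 (0.13 log units; within the scatter), so on this core the change makes no clear difference. Set beside the earlier step, the comparison stays unresolved: the same change on two cores in this assay, an at least 3.1-fold higher number (0.49 log units; beyond the scatter) from compound 1 to compound 2 and a 1.3-fold higher number (0.13 log units; within the scatter) from compound 3 to compound 4; the limit leaves it open whether they differ. The compounds therefore do not show that the change carries over from one core to the other with the same size, nor that its size depends on the core: the limit of > 5000000 nM in this assay, at which 1 of the 4 values shown sits.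

Still open, going by these compounds, is how a longer chain, an acetyl group or a carboxylic acid on that amine nitrogen would read on either core. Only ethyl and ethoxycarbonyl can be compared here, so no wider trend follows.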